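The compounds below may be only part of what the source reports. "The series", "measured", "known", "first", "only" and "open" are said of these compounds alone.

Compound 3 `c1ccc(-c2ncnc3c2ncn3C2CCOCC2)cc1` is known in a functional assay on K562 cells (Homo sapiens), read by thymidine incorporation (a lower number here means a stronger inhibitor, a higher number a weaker inhibitor), only by a limit: compound 3 gives < 10 ug/mL, which is a limit rather than a number. Compound 1 `c1csc(-c2[nH]cnc3ncnc2-3)c1`, which also carries thiophen-2-yl, likewise gives only a limit in this assay, < 10 ug/mL. Compound 2 `c1coc(-c2ncnc3c2ncn3CC2CCCCC2)c1` gives a number, 60 ug/mL in this assay. Compound 3 therefore cannot be placed more closely than the limit of < 10 ug/mL in this assay, at which 2 of the 3 values shown sit. Compound 4 `c1csc(-c2ncnc3c2ncn3C2CCOCC2)c1` differs from compound 3 in one place, thiophen-2-yl in place of phenyl on an aromatic carbon. For the measured compounds named here, no measured step covers this exchange. Against that background the step is expected to be none beyond the scatter, a step that the limit leaves unreadable from compound 3 to compound 4. Compound 4 is estimated at 5 ug/mL, within 1 ug/mL to 15 ug/mL, most likely reported again as a limit.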

Compound 4, half-maximal inhibitory concentration: 23 ug/mL
Estimate against measurement, compound 4: 4.6-fold (0.66 log units) below; measured number outside the range, above it.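

In this assay, putting thiophen-2-yl in place of phenyl on this aromatic carbon gives an at least 2.3-fold higher number from compound 3 to compound 4 (0.36 log units; beyond the scatter). For the compounds shown here, this is the first readable step at this position, and it shows that the two aromatic rings are not interchangeable here. Its true size stays open because compound 3 is known only by a limit: the limit of < 10 ug/mL in this assay, at which 2 of the 4 values shown sit.

From the compounds shown here alone, how an amine or a pyridin-3-yl ring on this carbon would read remains open. Going by these compounds alone, compound 2, with its furan-2-yl, differs from compound 4 in more than one place and gives no step.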